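The compounds below may be only part of what the source reports. "The series", "measured", "known", "first", "only" and "open" are said of these compounds alone.

Working notes on the ester series.

Compound 3 `CCCC(=O)Oc1ccc(/C=C/COC(C)=O)cc1OC` gives, in a functional assay on HCT-15 cells (Homo sapiens) for antiproliferative activity, read by sulforhodamine B assay, with a stated time of 72 h (a lower number here means a stronger inhibitor, a higher number a weaker inhibitor), 17100 nM. Among the compounds with values here, compound 1 `CC[C@H](C)C(=O)Oc1ccc(/C=C/COC(C)=O)cc1OC` differs from compound 3 by methyl in place of hydrogen on a saturated chain carbon bound to a carbonyl carbon and a saturated chain carbon and in this assay compound 1 gives 4580 nM; the step of a 3.7-fold lower number from compound 3 to compound 1 (0.57 log units; beyond the scatter) is the only measured instance of this change so far. Compound 2 `CCCC(=O)OC/C=C/c1ccc(OC(C)=O)c(OC)c1` gives 22800 nM in this assay; its number and that of compound 3 lie within the usual scatter of one another, so no order between the two is claimed. The cores of compound 2 and compound 3 are built from the same atoms joined differently; the difference between the two cores is not broken down here.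

Compound 4 `CC[C@H](C)C(=O)OC/C=C/c1ccc(OC(C)=O)c(OC)c1` is not yet measured. It differs from compound 2 by methyl in place of hydrogen on a saturated chain carbon bound to a carbonyl carbon and a saturated chain carbon, the same change as that from compound 3 to compound 1, at the same kind of place. Resting only on the single measured step from compound 3 to compound 1, a step of similar size is expected from compound 2 to compound 4, a 3.0-fold lower number from compound 2 to compound 4 (0.48 log units; beyond the scatter), with wide uncertainty since the core is rearranged. Compound 4 is therefore estimated at 7500 nM in this assay, between 3500 nM and 16000 nM.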

Compound 4, half-maximal inhibitory concentration: 34100 nM
The estimate for compound 4 lay 4.5-fold (0.66 log units) below the measured number; the whole stated range lies below it.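

In this assay, methyl in place of hydrogen on a saturated chain carbon bound to a carbonyl carbon and a saturated chain carbon gives a 1.5-fold higher number from compound 2 to compound 4 (0.17 log units; within the scatter), so this propyl to sec-butyl change produces no readable shift on the core of compound 2. Set beside the earlier step, the same change does not carry over from one core to the other: the same change on two cores in this assay, a 3.7-fold lower number (0.57 log units; beyond the scatter) from compound 3 to compound 1 and a 1.5-fold higher number (0.17 log units; within the scatter) from compound 2 to compound 4, 5.6-fold (0.75 log units) apart, beyond the scatter of two such steps. This shows that the step seen on the core of compound 3 cannot be assumed to hold on the rearranged core of compound 2, but with one pair on each core it does not show which feature of the rearrangement separates the two steps, nor how any other change would transfer.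

The compounds shown leave open whether a longer chain or an amine in place of the sec-butyl group would also behave differently on the two cores. As far as these compounds go, whether the opposite configuration of the sec-butyl group follows the same course on either core also remains open.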